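The source may hold more compounds than are shown below. What is called first, only, known or untested is meant among the compounds shown, and "the series" means these compounds.

Measured compounds:
- compound 1, `Nc1ccccc1NC(=O)c1ccc(CSC(=S)N2CCN(Cc3ccccn3)CC2)cc1`: 23.4%
- compound 2, `Nc1ccccc1NC(=O)c1ccc(CSC(=S)N2CCN(c3ccc(Cl)cc3)CC2)cc1`: 15%
- compound 3, `CN1CCN(C(=S)SCc2ccc(C(=O)Nc3ccccc3N)cc2)CC1`: 29.6%

These values come from a functional assay on MGC-803 cells (Homo sapiens) for antiproliferative activity, read by CCK-8 assay, with a stated time of 72 h, tested at 2 uM; a lower number here means a weaker effect, a higher number a stronger effect of the compound at the concentration tested. Of the three numbers, compound 3 shows the largest, yet its gap to compound 1 is within the scatter, as a number 6.2 percentage points higher from compound 1 to compound 3 (within the scatter) tells, while the gap to compound 2 is beyond it, as a number 14.6 percentage points higher from compound 2 to compound 3 (beyond the scatter) tells. Compound 4, `Nc1ccccc1NC(=O)c1ccc(CSC(=S)N2CCN(C3CCCCC3)CC2)cc1`, arises from compound 3 by a single change: cyclohexyl in place of methyl on an amine nitrogen in a ring. Both steps reaching compound 3 replaced a larger group on that nitrogen by a smaller one and raised the number, so this change in the other direction is expected to lower it by a modest amount, estimated as a number 7.6 percentage points lower from compound 3 to compound 4 (within the scatter). Compound 4 is therefore expected to give 22%, within 10% to 34%.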

Compound 4, a percentage reported as inhibition, at one concentration (the size of the read-out at that concentration, not a potency): 16.9%
Beside the measured number, compound 4's estimate is 5.1 percentage points above it; low and high end bracket the measured number.
By their numbers in this assay, from the lowest: compounds 2, 4, 1 and 3 (each within the scatter of the next, the first and the last beyond it).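

Cyclohexyl on the amine nitrogen in the ring shows that a bulkier saturated group also falls short of methyl, with a number 12.7 percentage points lower from compound 3 to compound 4 (beyond the scatter). It cannot be told apart from the aromatic 4-chlorophenyl, with a number 1.9 percentage points higher from compound 2 to compound 4 (within the scatter), or from (pyridin-2-yl)methyl, with a number 6.5 percentage points lower from compound 1 to compound 4 (within the scatter), although compound 1 itself stays within the scatter of compound 3 and so goes against any simple rule that larger groups give lower numbers. No measurement here explains these differences. Still open, from the compounds shown here alone, is how hydrogen or an ethyl group on that nitrogen would compare with methyl, and whether a hydroxyethyl chain there would change the picture.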